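Taking the halogens off the aryl ring of compound 1

The source may report more compounds than this note shows. Statements on the series, on what has been measured and on what is new or still open speak of the compounds shown alone.

In a functional assay on HCT-116 cells (Homo sapiens) for inhibition, read by MTT assay, with a stated time of 72 h (a lower number here means a stronger inhibitor, a higher number a weaker inhibitor), compound 1 `COc1cc2c(Oc3ccc(NC(=O)c4nn(-c5ccc(F)c(Cl)c5)cc(C)c4=O)cc3)ccnc2cc1OCCCCCCC(=O)NO` gives 370 nM. Among the measured compounds shown here, only one other measured compound is available for comparison: compound 2 `COc1cc2c(Oc3ccc(NC(=O)c4nn(-c5ccccc5C)cc(C)c4=O)cc3)ccnc2cc1OCCCCCC(=O)NO` gives 290 nM. These two values lie within the usual scatter of repeated measurements, so neither compound can be ranked against the other.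

The next compound, compound 3 `COc1cc2c(Oc3ccc(NC(=O)c4nn(-c5ccccc5)cc(C)c4=O)cc3)ccnc2cc1OCCCCCCC(=O)NO`, keeps the core of compound 1 and changes one group: phenyl in place of 3-chloro-4-fluorophenyl on an aromatic nitrogen. The fluorine and the chlorine go, while the six-membered aromatic ring of carbon stays.

For the measured compounds named here, no measured pair here shows this swap on its own, so the data give no direct size for it. In this assay, no step beyond the scatter is expected. Going by the values given here, the only guide is the narrow span of the measured numbers, with compound 1 at 370 nM and compound 2 at 290 nM. The estimated step of a 1.2-fold lower number from compound 1 to compound 3 (0.09 log units; within the scatter) stays within the scatter and has no firm direction. For compound 3 the expected value is 300 nM, with an estimated range from 110 nM to 800 nM.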

Compound 3, half-maximal inhibitory concentration: 150 nM
Estimate against measurement, compound 3: 2.0-fold (0.30 log units) above, and the stated range covers the measured number.
By their numbers in this assay, from the lowest: compounds 3, 2 and 1 (each within the scatter of the next, the first and the last beyond it).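

Compound 1 and compound 2 differ in more than one place, so they could not show what the aryl group on the aromatic nitrogen contributes, but this pair isolates that change. In this assay, taking away the fluorine and the chlorine gives a 2.5-fold lower number from compound 1 to compound 3 (0.39 log units; beyond the scatter) while the rest of compound 1 stays the same, so this position does respond to its substituents, if only modestly, and the bare phenyl ring of compound 3 gives the stronger inhibition of the two. No measurement here explains why the number falls, and the step alone cannot separate an effect on the cells from any other cause.

Both halogens leave together. The step cannot be divided between them, and a 3-chlorophenyl or a 4-fluorophenyl group would be needed to show whether one halogen accounts for most of it. As far as these compounds go, it also remains open whether a methoxy group on this phenyl ring, or an amine in that place, would lower the number further or raise it again, and whether the same step would appear with a different chain on the shared core.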